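The source may report more compounds than this note shows. Statements on the series, on what has been measured and on what is new or still open speak of the compounds shown alone.

Measured in a functional assay on HepG2 cells (Homo sapiens) for inhibition, read by MTT assay, with a stated time of 48 h; on this read-out higher numbers stand for weaker inhibition and lower numbers for stronger inhibition:
- compound 1 `CS(=O)(=O)c1ccc(-c2nc3ccccn3c2Sc2ccccc2)cc1` gives 13200 nM
- compound 2 `COc1ccc(-c2nc3ccccn3c2Sc2ccccc2)cc1` gives 54200 nM

For the measured compounds named here, compound 2 has the higher of these two numbers, with compound 1 as its only neighbour. Compound 3 `c1ccc(Sc2c(-c3cccs3)nc3ccccn23)cc1` is derived from compound 2 by this change: thiophen-2-yl in place of 4-methoxyphenyl on an aromatic carbon. Thiophen-2-yl takes the place of 4-methoxyphenyl on an aromatic carbon. Going by the values given here, only one measured step bears on this: a 4.1-fold higher number from compound 1 to compound 2 (0.61 log units; beyond the scatter). That modest step altered the group that now leaves, so it is only a rough guide. A step of similar or smaller size is expected, more likely downward, since compound 2 stands at 54200 nM at the top of the measured numbers. The expected step is a 2.2-fold lower number from compound 2 to compound 3 (0.34 log units; beyond the scatter). In this assay the estimate for compound 3 is 25000 nM, with an expected range of 9000 nM to 70000 nM.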

Compound 3, half-maximal inhibitory concentration: 17100 nM
Estimate against measurement, compound 3: 1.5-fold (0.16 log units) above, within the range that was stated.
By their numbers in this assay, from the lowest: compounds 1 and 3 (each within the scatter of the next); then compound 2.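

Swapping 4-methoxyphenyl for thiophen-2-yl in this assay gives a 3.2-fold lower number from compound 2 to compound 3 (0.50 log units; beyond the scatter), so this position does not need a six-membered ring and accepts a five-membered aromatic ring with fewer heavy atoms. Compound 3 also lies within the scatter of compound 1, so the methylsulfonyl group of compound 1 is not needed to reach that level. On these data alone, whether an amine or a carboxylic acid on the ring at this position would shift the number further remains open. Why the number changed also stays open, with no supporting measurement available to explain it.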